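This account rests on a few compounds, and the source may have more. Where it says the series, first, only, none or still open, it means among the compounds named here.

For the measured compounds named here, compound 3 `CN(C)C(=O)c1cc2cnc(Nc3ccc(NC(=O)CCCCN=C=S)cc3)nc2n1C1CCCC1` sits in the middle of the three numbers measured so far. In a functional assay on NCI-H1299 cells (Homo sapiens) for inhibition, read by CCK-8 assay, with a stated time of 72 h, tested at 1 uM (on this read-out lower numbers stand for a weaker effect and higher numbers for a stronger effect at the one concentration tested), compound 3 gives 58.6%, while compound 1 `CN(C)C(=O)c1cc2cnc(Nc3ccc(C(=O)NCCCN=C=S)cc3)nc2n1C1CCCC1` gives 65.1% and compound 2 `CN(C)C(=O)c1cc2cnc(Nc3ccc(C(=O)NCCCCCN=C=S)cc3)nc2n1C1CCCC1` gives 50.3%. Compound 3 lies within the scatter of both: a number 6.5 percentage points lower from compound 1 to compound 3 (within the scatter) and a number 8.3 percentage points higher from compound 2 to compound 3 (within the scatter). Going by the values given here, the only step beyond the scatter is the lengthening of the chain that carries the end group, where a number 14.8 percentage points lower from compound 1 to compound 2 (beyond the scatter).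

Compound 4 `CN(C)C(=O)c1cc2cnc(Nc3ccc(N=C=S)cc3)nc2n1C1CCCC1` is not yet measured. It differs from compound 3 by a group of 3 heavy atoms (1 carbon, 1 nitrogen, 1 sulfur; no ring) in place of a group of 10 heavy atoms (6 carbon, 2 nitrogen, 1 oxygen, 1 sulfur; no ring), on an aromatic carbon. This removes the whole chain with its amide and leaves the three-atom end group directly on the ring. Among the compounds with values here, no measured pair makes that kind of cut; the only chain change seen runs the other way and adds length, so it gives a direction only loosely. On these data alone, a shorter chain was not worse among the measured compounds, but an absent chain is untested, and the expected step is therefore small but very uncertain.

Compound 4 is estimated to give 58% in this assay, with a range from 35% to 78%, which means an expected step of a number 0.6 percentage points lower from compound 3 to compound 4 (within the scatter).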

Compound 4, a percentage reported as inhibition, at one concentration (the size of the read-out at that concentration, not a potency): 46.9%
For compound 4 the middle estimate is 11.1 percentage points above the measured one; measured number inside the range.
By their numbers in this assay, from the lowest: compounds 4, 2, 3 and 1 (each within the scatter of the next, the first and the last beyond it).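

In this assay, this position, on an aromatic carbon para to a large group, turns out not to be indifferent to the loss of the chain: with the end group of 3 heavy atoms placed directly on the ring, the steps are a number 11.7 percentage points lower from compound 3 to compound 4 (beyond the scatter) and a number 18.2 percentage points lower from compound 1 to compound 4 (beyond the scatter). The picture is not uniform, and compound 2 goes against any simple rule that a chain is better than none, as its step is a number 3.4 percentage points lower from compound 2 to compound 4 (within the scatter), so its longer chain and no chain at all cannot be told apart here. Nothing available explains these steps. Compound 1 and compound 3, with their shorter chains, stand apart from compound 4, and the data shown do not tell what lies behind this.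

The compounds shown leave open whether the amide or the chain length accounts for the difference, a question that a plain carbon chain carrying the same end group on this ring would help to answer. Also open, on these data alone, is how much the end group itself contributes, which could be tested by putting a simple amine in its place at the end of the chain.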